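The compounds below may be only part of what the source reports. "The series", "measured", "known", "first", "only" and "open" are said of these compounds alone.

Going by the values given here, compound 1 `Cc1ccc(NC(=O)Nc2cc(-c3ccccc3C(=O)O)ccc2Oc2ccccc2C(C)(C)C)cc1` holds the only plain number in an assay on HeLa cells for inhibition of Indoleamine 2,3-dioxygenase 1 (Homo sapiens), with stated times of 1 h and 18 h; a lower number here means a stronger inhibitor, a higher number a weaker inhibitor: compound 1 gives 70 nM. Compound 2 `Cc1ccc(NC(=O)Nc2cc(-c3ccc(C(=O)O)cc3)ccc2Oc2ccccc2C(C)(C)C)cc1` shows only a limit in this assay, namely > 1000 nM. Among the compounds with values here, the single measured step, an at least 14-fold higher number from compound 1 to compound 2 (1.15 log units; beyond the scatter), moves the carboxylic acid and rests on (the limit of > 1000 nM in this assay, at which 1 of the 2 values shown sits). Compound 3 `Cc1ccc(NC(=O)Nc2cc(-c3ccccc3C(=O)O)ccc2Nc2ccccc2C(C)(C)C)cc1` differs from compound 1 in another way: (2-(tert-butyl)phenyl)amino in place of 2-(tert-butyl)phenoxy on an aromatic carbon. Within the data shown here, no measured step changes this linking atom, so the shift from compound 1 to compound 3 is expected to stay within the scatter, a 1.4-fold higher number from compound 1 to compound 3 (0.15 log units; within the scatter). Compound 3 is therefore estimated at 100 nM, between 35 nM and 300 nM.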

Compound 3, half-maximal inhibitory concentration: 600 nM
Beside the measured number, compound 3's estimate is 6.0-fold (0.78 log units) below it, and the stated range ends below it.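

Going by these compounds alone, the linking atom of this group matters in this assay, although it is the only atom that changes: an 8.6-fold higher number from compound 1 to compound 3 (0.93 log units; beyond the scatter). The heavy-atom count stays the same and the new group carries one hydrogen-bond donor that the old one lacks, so the carboxylic acid is not the only sensitive place on the shared core. Nothing shown here explains why this exchange weakens inhibition. On these data alone, it remains open how a sulfur atom or a methylene group would behave as the link, and whether a methyl group on the nitrogen would bring the number back towards that of compound 1.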